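Chlorine on the aromatic ring: what compound 2 suggests

A few compounds are considered here, and "the series" means these few. Any claim that something is new, unique, unknown or untested is made for them only; others in the source may bear on it.

Three hydrazones sharing one core have been measured. In an ADME assay on cells (Mus musculus, strain BALB/C) for cytotoxicity, read by MTT assay, with a stated time of 24 h (on this read-out lower numbers stand for higher toxicity in this test and higher numbers for lower toxicity in this test), compound 1 `Cc1ccc(C(=O)N/N=C/c2ccccc2F)c(O)c1` gives 362000 nM, compound 2 `Cc1ccc(C(=O)N/N=C/c2ccccc2)c(O)c1` gives 578000 nM, and compound 3 `Cc1ccc(C(=O)N/N=C/c2ccccc2O)c(O)c1` gives 761000 nM. Compound 2 stands second highest of the three numbers; its nearest neighbour is compound 3, and a 1.3-fold higher number from compound 2 to compound 3 (0.12 log units; within the scatter), while the furthest is compound 1, and a 1.6-fold higher number from compound 1 to compound 2 (0.20 log units; within the scatter). The remaining comparison, a 2.1-fold higher number from compound 1 to compound 3 (0.32 log units; beyond the scatter), is the only one reaching beyond the scatter.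

Compound 4 `Cc1ccc(C(=O)N/N=C/c2ccc(Cl)cc2)c(O)c1` has not been measured in this assay. It differs from compound 2 in a single place: chloro in place of hydrogen on an aromatic carbon. Among the measured compounds shown here, no measured pair carries exactly this change. The closest guide is the fluoro case, where a 1.6-fold higher number from compound 1 to compound 2 (0.20 log units; within the scatter), and the hydroxy case, where a 1.3-fold higher number from compound 2 to compound 3 (0.12 log units; within the scatter); both of these substitutions of one ring hydrogen left the number within the scatter. On that basis no step beyond the scatter is expected for this assay, with a slight lean toward a lower number because compound 1 gives 362000 nM. Compound 4 is therefore estimated to show a 1.3-fold lower number from compound 2 to compound 4 (0.11 log units; within the scatter). The expected value for compound 4 is 450000 nM, within a range of 200000 nM to 950000 nM.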

Compound 4, half-maximal cytotoxic concentration: 116000 nM
Compound 4: the middle estimate sits 3.9-fold (0.59 log units) above what was measured, and the stated range ends above it.
By their numbers in this assay, from the lowest: compound 4; then compounds 1, 2 and 3 (each within the scatter of the next, the first and the last beyond it).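

In this assay, putting chloro in place of a ring hydrogen of compound 2, para to a large group, gives a 5.0-fold lower number from compound 2 to compound 4 (0.70 log units; beyond the scatter), and this is the only step shown from compound 2 that goes beyond the scatter, here toward higher toxicity in this test. Among the compounds shown here, the earlier single changes on that ring, a 1.6-fold higher number from compound 1 to compound 2 (0.20 log units; within the scatter) and a 1.3-fold higher number from compound 2 to compound 3 (0.12 log units; within the scatter), stayed within the scatter, but neither involved chloro or this place, so this result is the first sign that a single heavy atom on this ring can move the number so clearly. No measurement at hand explains the step.

The compounds shown carry chloro at this one place only and show no other group there, so they leave open whether the step belongs to chloro itself or to the place it occupies. Fluoro, hydroxy, bromo, methoxy, an amine or a carboxylic acid at the same place, together with chloro elsewhere on this ring, would be needed to separate the two.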